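Removing a bromine from the indole core of compound 3

The compounds below may be only part of what the source reports. "The series", "measured", "known", "first", "only" and "open" are said of these compounds alone.

Compound 1, `COc1ccc(Cn2cc(/C=N\NC(=O)c3c[nH]c4ccc(Br)cc34)c3ccc(F)cc32)cc1`, is the weakest of the three measured compounds: in a functional assay on DU-145 cells (Homo sapiens) for cytotoxicity (on this read-out lower numbers stand for stronger inhibition and higher numbers for weaker inhibition), compound 1 gives 67500 nM. Compound 2, `COc1ccc(Cn2cc(/C=N\NC(=O)c3c[nH]c4ccccc34)c3ccc(F)cc32)cc1`, differs from it only by hydrogen in place of bromo on an aromatic carbon, and in this assay compound 2 gives 16200 nM, so this change made a 4.2-fold lower number from compound 1 to compound 2 (0.62 log units; beyond the scatter). Compound 3, `O=C(N/N=C\c1cn(Cc2ccc(Cl)cc2)c2ccc(Br)cc12)c1c[nH]c2ccccc12`, carries a different core; how that core differs from the core of compound 1 is not broken down here. In this assay compound 3 gives 3600 nM, the lowest number of the three.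

Compound 4, `O=C(N/N=C\c1cn(Cc2ccc(Cl)cc2)c2ccccc12)c1c[nH]c2ccccc12`, is not yet measured. Going by the values given here, it arises from compound 3 by hydrogen in place of bromo on an aromatic carbon, which is the same change, at the same kind of place, as the one from compound 1 to compound 2. The step from compound 3 to compound 4 is therefore expected to be of similar size, a 4.0-fold lower number from compound 3 to compound 4 (0.60 log units; beyond the scatter), because of a 4.2-fold lower number from compound 1 to compound 2 (0.62 log units; beyond the scatter) seen on the earlier pair. On that basis compound 4 is estimated to give about 900 nM in this assay, most likely somewhere between 350 nM and 2500 nM.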

Compound 4, half-maximal inhibitory concentration: 52100 nM
Compound 4: middle estimate off by 58-fold (1.76 log units), on the low side; the whole stated range lies below it.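

Replacing the bromo with hydrogen did not behave the same way on the two cores: in this assay, the change gave a 14-fold higher number from compound 3 to compound 4 (1.16 log units; beyond the scatter), whereas on the earlier pair the number fell. Going by these compounds alone, a change that looks identical on paper can therefore give opposite results, and the step seen on one core was a poor guide to the step on the other: the same change on two cores in this assay, a 4.2-fold lower number (0.62 log units; beyond the scatter) from compound 1 to compound 2 and a 14-fold higher number (1.16 log units; beyond the scatter) from compound 3 to compound 4, 60-fold (1.78 log units) apart, beyond the scatter of two such steps With only two pairs, this shows that the outcome depends on the rest of the molecule, but it does not show which feature of the two cores decides the direction, nor why the size of the step differs.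

The compounds shown leave open whether a third core would follow the lower or the higher number when this bromo is replaced with hydrogen. They also leave open what another group on this aromatic carbon, such as a methyl group or an amine, would do on either core.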